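This account rests on a few compounds, and the source may have more. Where it says the series, first, only, none or still open, it means among the compounds named here.

Series notes on this set. In a functional assay on MCF7 cells (Homo sapiens) for antiproliferative activity, read by MTT assay, with a stated time of 48 h (on this read-out higher numbers stand for weaker inhibition and lower numbers for stronger inhibition), compound 1 `COc1ccc(-n2nncc2CN2C(=O)C3(C(C#N)=C(N)Oc4c3c3nc5ccccc5nc3c3ccccc43)c3ccccc32)cc1` reaches only the limit of the assay and gives > 50000 nM, not a number. Compound 2 `CC(=O)Nc1ccc(-n2nncc2CN2C(=O)C3(C(C#N)=C(N)Oc4c(N)cc5nc6ccccc6nc5c43)c3ccccc32)cc1` likewise gives only the limit > 50000 nM in this assay. Compound 2 thus stands where every shown value stands, at the edge of the read-out, as shown by the limit of > 50000 nM in this assay, at which 2 of the 2 values shown sit; no step between measured compounds can be given, and two limits show no difference between compound 1 and compound 2. Compound 3 `COc1cc(-n2nncc2CN2C(=O)C3(C(C#N)=C(N)Oc4c(N)cc5nc6ccccc6nc5c43)c3ccccc32)c(OC)cc1Cl` is not yet measured. It differs from compound 2 by 4-chloro-2,5-dimethoxyphenyl in place of 4-acetamidophenyl on an aromatic nitrogen. With both shown values at the limit there is no measured step by which to gauge the size of the change. The step expected is a step that the limit leaves unreadable from compound 2 to compound 3, that is none beyond the scatter, and most likely another limit. Compound 3 is estimated at 60000 nM in this assay, with a range from 20000 nM to 200000 nM.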

Compound 3, half-maximal inhibitory concentration: > 50000 nM
Compound 3: no number, only a limit; the forecaster's own chance of this, stated with the estimate: 75%; the middle value does not contradict the limit.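

In this assay, among these compounds, compound 3 gives > 50000 nM, a limit and not a number, so no step from compound 2 to compound 3 can be read. The compounds shown leave open whether any change to the shared core or its aromatic substituent gives a measurable value in this assay.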